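The source may hold more compounds than are shown below. What is called first, only, known or untested is meant among the compounds shown, and "the series" means these compounds.

The measured compounds:

Compound 1, `COc1cc(-c2cc(/C=C/C(=O)c3ccc(Cl)c(Cl)c3)[nH]n2)cc(OC)c1OC`: 47%
Compound 2, `COc1ccc(C(=O)/C=C/c2cc(-c3cc(OC)c(OC)c(OC)c3)n[nH]2)cc1OC`: -88%
Compound 3, `COc1ccc(C(=O)/C=C/c2cc(-c3cc(OC)c(OC)c(OC)c3)n[nH]2)cc1`: -65%

In a functional assay on BT-549 cells (Homo sapiens) for cytotoxicity, read by sulforhodamine B assay, with a stated time of 48 h, tested at 10 uM (on this read-out lower numbers stand for a stronger effect and higher numbers for a weaker effect at the one concentration tested), compound 3 stands second highest of the three numbers. Its nearest neighbour is compound 2, with the step of a number 23 percentage points higher from compound 2 to compound 3 (beyond the scatter); its furthest is compound 1, with the step of a number 112 percentage points lower from compound 1 to compound 3 (beyond the scatter). Compound 4, `COc1cc(-c2cc(/C=C/C(=O)c3ccc(F)c(F)c3)[nH]n2)cc(OC)c1OC`, shares the core of compound 3 and differs from it in one place: 3,4-difluorophenyl in place of 4-methoxyphenyl on a carbonyl carbon.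

Among the compounds with values here, the step that bears on this change is the one from compound 1 to compound 3, where a halogen-bearing phenyl gave way to a methoxy-bearing phenyl on the same carbonyl carbon, and the number in this assay fell by a large amount. The step of a number 135 percentage points lower from compound 1 to compound 2 (beyond the scatter) points the same way. Compound 4 reverses that direction, putting a halogen-bearing phenyl back in place of the methoxy-bearing one, though with fluorine rather than chlorine. A large rise in this assay is therefore expected, though how close it comes to compound 1 is uncertain. For compound 4 the expected step is a number 80 percentage points higher from compound 3 to compound 4 (beyond the scatter). Compound 4 is estimated at 15%, with a range from -40% to 55%.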

Compound 4, a percentage reported as activity, at one concentration (the size of the read-out at that concentration, not a potency): 23%
Estimate against measurement, compound 4: 8 percentage points below; the range from low to high includes it.
By their numbers in this assay, from the lowest: compound 2; then compound 3; then compound 4; then compound 1.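

In this assay, the 3,4-difluorophenyl group shows that a weak effect on this carbonyl carbon is not tied to chlorine alone: the number climbs back with a number 88 percentage points higher from compound 3 to compound 4 (beyond the scatter) and with a number 111 percentage points higher from compound 2 to compound 4 (beyond the scatter), so both methoxy-bearing compounds keep a much stronger effect than either halogen-bearing compound. The two halogen-bearing groups are still not interchangeable, since a number 24 percentage points lower from compound 1 to compound 4 (beyond the scatter) is a modest change but one beyond the usual scatter, and the difluoro compound gives the stronger effect of the two. Nothing measured here explains why the groups on this carbonyl carbon differ in this way.

The compounds shown leave open whether the strong effect depends on the methoxy groups themselves or would also appear with other groups on this phenyl ring. A phenyl ring carrying an amine or a carboxylic acid in place of the methoxy or halogen atoms, or an unsubstituted phenyl ring, would help separate these possibilities, and these readings speak only of a stronger or weaker effect at the one concentration tested.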